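From compound 2 to compound 4: an aryl exchange

The source may report more compounds than this note shows. Statements on the series, on what has been measured and on what is new or still open speak of the compounds shown alone.

Values from a functional assay on SK-MEL-28 cells (Homo sapiens) for inhibition, read by MTT assay, with a stated time of 48 h (a lower number here means a stronger inhibitor, a higher number a weaker inhibitor), stand below.
- compound 1 `CS(=O)(=O)c1ccc(-c2nc3ccccn3c2Sc2ccccc2)cc1` at 61900 nM
- compound 2 `C(=C/c1nc2ccccn2c1Sc1ccccc1)\c1ccccc1` at 65400 nM
- compound 3 `Cc1ccc(-c2nc3ccc(C)cn3c2Sc2ccccc2)cc1` at 95700 nM

Compound 2 at 65400 nM lies within the scatter of both compound 1 and compound 3, so these values give no order among the three. Compound 4 `Clc1ccc(-c2nc3ccccn3c2Sc2ccccc2)cc1` has not yet been measured in this assay and differs from compound 2 as follows: 4-chlorophenyl in place of 2-phenylethenyl on an aromatic carbon.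

Within the data shown here, no two measured compounds differ in one place only, so no direct step is available for this exchange. Compound 1 at 61900 nM and compound 3 at 95700 nM both carry a six-membered aromatic ring of carbon only on that aromatic carbon, as compound 4 does, and neither stands beyond the scatter from compound 2. No step beyond the scatter is therefore expected in this assay in either direction. The estimated step of a 1.1-fold higher number from compound 2 to compound 4 (0.03 log units; within the scatter) is expected to stay within the scatter. For compound 4 the expected value is 70000 nM with an estimated range from 35000 nM to 140000 nM as its span.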

Compound 4, half-maximal inhibitory concentration: 73100 nM
The estimate for compound 4 lay 1.0-fold (0.02 log units) below the measured number, and the stated range covers the measured number.
By their numbers in this assay, from the lowest: compounds 1, 2, 4 and 3 (each within the scatter of the next).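

In this assay, among these compounds, the exchange of 2-phenylethenyl for 4-chlorophenyl, on the aromatic carbon of the five-membered aromatic ring, gives a 1.1-fold higher number from compound 2 to compound 4 (0.05 log units; within the scatter) and so provides the first direct reading at this position: the double bond outside aromatic rings can leave and a chlorine-bearing aryl group can enter without a step beyond the scatter. Chloro in place of methylsulfonyl on an aromatic carbon gives a 1.2-fold higher number from compound 1 to compound 4 (0.07 log units; within the scatter) and adds a second direct reading, in which these two groups are not separated in this assay. No supporting data bear on these two results, so nothing can be said about what lies behind them. On these data alone, both steps compare groups that each carry a six-membered aromatic ring of carbon only or sit on one, so it remains open whether an amine, a carboxylic acid or a longer saturated chain on the same aromatic carbon would give a step beyond the scatter. As far as these compounds go, the phenylsulfanyl group is common to all four compounds, and the effect of replacing it, for example with a benzylamine, also remains open.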